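Formamidine sulfonamides: oxazolyl substitution on the ketone-bearing core

The source may report more compounds than this note shows. Statements on the series, on what has been measured and on what is new or still open speak of the compounds shown alone.

Working notes on the series. Three compounds have numbers in a functional assay on MCF7 cells (Homo sapiens) for cytotoxicity, read by sulforhodamine B assay, with a stated time of 48 h; a lower number here means a stronger inhibitor, a higher number a weaker inhibitor. Compound 1 `Cc1c(C#N)c(/N=C/Nc2ccc(S(N)(=O)=O)cc2)nc2c1CCCC2` carries a free sulfonamide on the saturated core; in this assay compound 1 gives only a limit, > 10 ug/mL. Compound 2 `Cc1cc(NS(=O)(=O)c2ccc(N/C=N/c3nc4c(c(C)c3C#N)CCCC4)cc2)no1` carries the 5-methyl-1,2-oxazol-3-yl group on the sulfonamide nitrogen, and in this assay compound 2 gives 1.95 ug/mL. Compound 3 `Cc1c(C#N)c(/N=C/Nc2ccc(S(N)(=O)=O)cc2)nc2c1C(=O)CC(C)(C)C2` keeps the free sulfonamide but has the ketone-bearing core, and in this assay compound 3 gives 2.62 ug/mL; the gap to compound 2 is within the scatter, so the two are not ordered.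

Compound 4 `Cc1cc(NS(=O)(=O)c2ccc(N/C=N/c3nc4c(c(C)c3C#N)C(=O)CC(C)(C)C4)cc2)no1` is not yet measured. It differs from compound 3 in one place: 5-methyl-1,2-oxazol-3-yl in place of hydrogen on a sulfonamide nitrogen. The same change has been measured once, on the saturated core, as an at least 5.1-fold lower number from compound 1 to compound 2 (0.70 log units; beyond the scatter); that step rests on (the limit of > 10 ug/mL in this assay, at which 1 of the 3 values shown sits), so its true size is only bounded from below.

For compound 4 the number in this assay is therefore expected to be lower than for compound 3 by a step of about a 3.7-fold lower number from compound 3 to compound 4 (0.57 log units; beyond the scatter), in the same direction as the measured step. The estimate for compound 4 is 0.7 ug/mL, with a likely range from 0.25 ug/mL to 2 ug/mL.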

Compound 4, half-maximal inhibitory concentration: 1.9 ug/mL
Beside the measured number, compound 4's estimate is 2.7-fold (0.43 log units) below it, within the range that was stated.
By their numbers in this assay, from the lowest: compounds 4, 2 and 3 (each within the scatter of the next). At a limit, above all of these: compound 1.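

In this assay, placing 5-methyl-1,2-oxazol-3-yl on the sulfonamide nitrogen of the ketone-bearing core gives a 1.4-fold lower number from compound 3 to compound 4 (0.14 log units; within the scatter), so on this core the change produces no separable difference in the number, unlike the clear step on the saturated core. The effect of this change at this position therefore differs with the core that carries it, and a single step on one core did not reveal this: the same change on two cores in this assay, an at least 5.1-fold lower number (0.70 log units; beyond the scatter) from compound 1 to compound 2 and a 1.4-fold lower number (0.14 log units; within the scatter) from compound 3 to compound 4, at least 3.7-fold (0.57 log units) apart, beyond the scatter of two such steps The size of that difference remains bounded on one side only, as the step on the saturated core starts from a limit rather than a number: the limit of > 10 ug/mL in this assay, at which 1 of the 4 values shown sits.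

Only hydrogen and 5-methyl-1,2-oxazol-3-yl appear on the sulfonamide nitrogen in the compounds shown, so it remains open whether an acetyl group or a longer alkyl chain there would also give different steps on the two cores. Also open is whether the close grouping of compounds 2, 3 and 4 holds in any assay other than this one, as all the numbers shown come from a single cell line and read-out.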